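A few compounds are considered here, and "the series" means these few. Any claim that something is new, unique, unknown or untested is made for them only; others in the source may bear on it.

Three compounds of this set share a core carrying three methoxy groups, and all three have been tested in a functional assay on PC-3 cells (Homo sapiens) for antiproliferative activity, read by MTT assay, tested at 1 uM; on this read-out higher numbers stand for a stronger effect at the one concentration tested and lower numbers for a weaker effect. Compound 1 `COc1ccc(/C=N/NC(=O)c2cc(OC)c(OC)c(OC)c2)c(OC)c1` gives 10% in this assay. Compound 2 `COc1cc(C2=NN(C(C)=O)C(c3cc(Cl)cc(Cl)c3)O2)cc(OC)c1OC`, in which the core is joined to a five-membered ring that holds two nitrogens and one oxygen, gives 52.7% in this assay. Compound 3 `COc1cc(C(=O)N/N=C/c2ccccc2C(F)(F)F)cc(OC)c1OC` gives 45% in this assay. On these numbers compound 2 stands highest of the three; compound 3 sits nearest to it, a gap that falls within the usual scatter, while compound 1 lies furthest below it, a gap that lies beyond the scatter.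

Compound 4 `COc1cc(C2=NN(C(C)=O)C(c3cccc(C(F)(F)F)c3)O2)cc(OC)c1OC` has not been measured. It differs from compound 2 in one place: 3-(trifluoromethyl)phenyl in place of 3,5-dichlorophenyl on a saturated ring carbon. Within the data shown here, no pair of measured compounds shows this exact change, so its size is open. The number for compound 4 is expected to stay close to that of compound 2, with a step of a number 6.7 percentage points lower from compound 2 to compound 4 (within the scatter) that should not reach beyond the scatter, since compound 3, which also bears a trifluoromethyl on its outer ring, gives 45%. Compound 4 is therefore estimated at 46%, within a range from 28% to 62%.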

Compound 4, a percentage reported as inhibition, at one concentration (the size of the read-out at that concentration, not a potency): 30.1%
For compound 4 the middle estimate is 15.9 percentage points above the measured one; the measured number falls inside the stated range.
By their numbers in this assay, from the lowest: compound 1; then compound 4; then compounds 3 and 2 (each within the scatter of the next).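

Replacing 3,5-dichlorophenyl with 3-(trifluoromethyl)phenyl on the saturated ring carbon brings a number 22.6 percentage points lower from compound 2 to compound 4 (beyond the scatter) in this assay and so shows that this position responds to what the outer ring carries. Compounds 2 and 4 are the only pair shown that differ in this one place, and both groups are a single carbon-only aromatic ring with no hydrogen-bond donors or acceptors, so even a swap between such similar rings can move the number. Nothing available here explains the drop.

On these data alone, it stays open whether an outer ring carrying an amine or a carboxylic acid, or a longer chain in place of the ring, would hold up or lower the number on this carbon. Also open, as far as these compounds go, is whether the same swap would act alike on another core, since compounds 1 and 3 differ from these two in more than one place.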